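The compounds below may be only part of what the source reports. "The series", "measured", "known", "first", "only" and "open" are said of these compounds alone.

Compound 2 `C=C(Br)C(=O)Nc1cccc(-c2cn3nc(-c4ccc(CC)cc4)sc3n2)c1` gives the lowest of the three numbers in a functional assay on L1210 cells (Mus musculus) for inhibition, read by cell counting, with a stated time of 2 days (a lower number here means a stronger inhibitor, a higher number a weaker inhibitor), at 2200 nM. Going by the values given here, compound 1 `CCc1ccc(-c2nn3cc(-c4cccc(N)c4)nc3s2)cc1` gives 6000 nM, and the step of a 2.7-fold lower number from compound 1 to compound 2 (0.44 log units; beyond the scatter) is the only single-point change measured here. Among the compounds with values here, compound 3 `Nc1cccc(-c2cn3nc(CCc4ccccc4)sc3n2)c1` gives 31000 nM; it differs from compound 1 in the group on the five-membered ring, and its higher number shows that this position matters, though no single step covers the change now in question. Compound 4 `C=C(Br)C(=O)Nc1cccc(-c2cn3nc(-c4cccc(OC)c4)sc3n2)c1` differs from compound 2 by 3-methoxyphenyl in place of 4-ethylphenyl on an aromatic carbon. Within the data shown here, with no measured step bearing directly on this exchange, a modest shift is expected: the estimate for compound 4 in this assay is 3000 nM, within 900 nM to 10000 nM, meaning an expected step of a 1.4-fold higher number from compound 2 to compound 4 (0.13 log units; within the scatter).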

Compound 4, half-maximal inhibitory concentration: 580 nM
Estimate against measurement, compound 4: 5.2-fold (0.71 log units) above, and the stated range ends above it.
By their numbers in this assay, from the lowest: compound 4; then compound 2; then compound 1; then compound 3.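

In this assay, the group on the aromatic carbon next to the ring nitrogen and the ring sulfur now has a measured step of its own: a 3.8-fold lower number from compound 2 to compound 4 (0.58 log units; beyond the scatter). The exchange keeps the count of heavy atoms but replaces a carbon-only group with one holding an oxygen and a hydrogen-bond acceptor, and it also moves the substituent on the phenyl ring. No evidence is available to explain the change. The compounds shown leave open whether the oxygen or the substituent's place matters, which 4-methoxyphenyl or 3-ethylphenyl would separate, and how 3-aminophenyl would compare.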